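A few compounds are considered here, and "the series" means these few. Any claim that something is new, unique, unknown or untested is made for them only; others in the source may bear on it.

Measured compounds in a functional assay on A549 cells (Homo sapiens) for antiproliferative activity, read by MTT assay, with a stated time of 72 h; a higher number here means a weaker inhibitor, a lower number a stronger inhibitor: compound 1, `NC1=NC2(CCSCC2)N(OCCCOc2ccc(Cl)c(Cl)c2)C(N)=N1`, gives 1 nM; compound 2, `NC1=NC2(CCSCC2)N(OCCCOc2cccc(Cl)c2)C(N)=N1`, gives 60 nM; compound 3, `NC1=NC2(CCOCC2)N(OCCCOc2ccc(Cl)c(Cl)c2)C(N)=N1`, gives 790 nM.

Within the data shown here, the one counted step among them, a 60-fold lower number from compound 2 to compound 1 (1.78 log units; beyond the scatter), comes from the change (chloro in place of hydrogen on an aromatic carbon). Compound 3 and compound 2 differ in their cores, and that difference is not broken down here. Compound 4, `NC1=NC2(CCOCC2)N(OCCCOc2cc(Cl)c(Cl)cc2Cl)C(N)=N1`, is not yet measured; it differs from compound 3 by chloro in place of hydrogen on an aromatic carbon. This is the same kind of change as that from compound 2 to compound 1, but not the same: here the entering chloro sits ortho to a large group, meta to a chloro group and para to a chloro group, whereas earlier it sat ortho to a chloro group and para to a large group. A smaller step is therefore expected than a 60-fold lower number from compound 2 to compound 1 (1.78 log units; beyond the scatter). The expected step is a 2.6-fold lower number from compound 3 to compound 4 (0.42 log units; beyond the scatter). Compound 4 is estimated at 300 nM, between 50 nM and 1500 nM.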

Compound 4, half-maximal inhibitory concentration: 680 nM
Compound 4: middle estimate off by 2.3-fold (0.36 log units), on the low side; low and high end bracket the measured number.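

In this assay, the same kind of change does not carry over in size from one core to the other, as the chloro entering on the aromatic ring gives only a 1.2-fold lower number from compound 3 to compound 4 (0.07 log units; within the scatter). The two steps differ clearly: the same change on two cores in this assay, a 60-fold lower number (1.78 log units; beyond the scatter) from compound 2 to compound 1 and a 1.2-fold lower number (0.07 log units; within the scatter) from compound 3 to compound 4, 52-fold (1.71 log units) apart, beyond the scatter of two such steps

This does not show that the core alone sets the size of the step. The chloro enters ortho to a chloro group in compound 1 but ortho to a large group in compound 4, and no pair shown separates place from core.

On these data alone, it remains open what the ring of compound 2 would give on the core of compound 3, which would allow a comparison at the same place. Also open, as far as these compounds go, is whether a fluoro or a methyl entering there would behave as chloro does.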